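Removing a Ring Methyl: Expected Effect on Growth Inhibition

The source may report more compounds than this note shows. Statements on the series, on what has been measured and on what is new or still open speak of the compounds shown alone.

Going by the values given here, in a functional assay on HT-29 cells (Homo sapiens) for antiproliferative activity, read by sulforhodamine B assay (on this read-out lower numbers stand for stronger inhibition and higher numbers for weaker inhibition), compound 1 `C/C(=N\Nc1nc2ccccc2o1)c1ccc(C)nn1` gives 6770 nM, the only number recorded in this set. Compound 2 `C/C(=N\N(C)c1nc2ccccc2o1)c1ccccn1` reaches only the assay limit of > 50000 nM in this assay. Compound 3 `C/C(=N\Nc1nc2ccccc2o1)c1cccnn1` differs from compound 1 by hydrogen in place of methyl on an aromatic carbon, set on an aromatic carbon of a six-membered aromatic ring with 2 nitrogen. Among the compounds with values here, no measured pair shows such a change, so its size is not known from these data; a small shift in this assay, within or only slightly beyond the scatter and leaning toward weaker inhibition, is expected. Compound 3 is estimated at 9000 nM, between 3500 nM and 25000 nM. The step of a 1.3-fold higher number from compound 1 to compound 3 (0.12 log units; within the scatter) is the expected outcome.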

Compound 3, half-maximal inhibitory concentration: 2640 nM
Compound 3: middle estimate off by 3.4-fold (0.53 log units), on the high side; measured number below the stated range.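

Replacing the methyl on this aromatic carbon, next to the ring nitrogen, with hydrogen gives a 2.6-fold lower number from compound 1 to compound 3 (0.41 log units; beyond the scatter) in this assay. The methyl is therefore not needed for growth inhibition in these cells, and this change moves the number toward stronger inhibition, not weaker. The compounds shown offer nothing that accounts for this gain.

From the compounds shown here alone, whether an ethyl, a methoxy or an amine at this position would extend or reverse the step remains open. So does whether a fluorine there would match hydrogen or methyl.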